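Aryl exchange at the shared core: outlook for compound 4

The source may hold more compounds than are shown below. What is called first, only, known or untested is meant among the compounds shown, and "the series" means these compounds.

Measured so far in a functional assay on MGC-803 cells (Homo sapiens) for inhibition, read by MTT assay, with a stated time of 72 h; on this read-out lower numbers stand for stronger inhibition and higher numbers for weaker inhibition:
compound 1 `COc1cc(-c2nc(SCc3cn(CC(=O)NC(=O)Nc4ccccn4)nn3)nc(Nc3ccc(C)cc3)c2C#N)cc(OC)c1OC` — 7030 nM
compound 2 `COc1cc(-c2nc(SCc3cn(CC(=O)NC(=O)Nc4ccccn4)nn3)nc(Nc3cccc(C(F)(F)F)c3)c2C#N)cc(OC)c1OC` — 8210 nM
compound 3 `COc1cc(-c2nc(SCc3cn(CC(=O)NC(=O)Nc4ccccn4)nn3)nc(Nc3ccc(Cl)cc3)c2C#N)cc(OC)c1OC` — 17500 nM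

Compound 1 gives the lowest number of the three in this assay; compound 2 sits within the scatter of it a 1.2-fold higher number from compound 1 to compound 2 (0.07 log units; within the scatter), while compound 3 lies beyond it a 2.5-fold higher number from compound 1 to compound 3 (0.40 log units; beyond the scatter), and the gap from compound 2 to compound 3 is also modest a 2.1-fold higher number from compound 2 to compound 3 (0.33 log units; beyond the scatter).

Compound 4 `Cc1ccc(Nc2nc(SCc3cn(CC(=O)NC(=O)Nc4ccccn4)nn3)nc(-c3ccc(C)cc3)c2C#N)cc1` differs from compound 1 at another place: 4-methylphenyl in place of 3,4,5-trimethoxyphenyl on an aromatic carbon. Going by the values given here, every measured step so far varies only the aryl on the amino nitrogen, so no measured step bears on this exchange, and the expectation for compound 4 can rest on compound 1 alone. The direction is open; the estimated step is a 2.0-fold higher number from compound 1 to compound 4 (0.30 log units; within the scatter), with a wide range. Compound 4 is estimated at 14000 nM, between 3500 nM and 56000 nM.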

Compound 4, half-maximal inhibitory concentration: 9890 nM
The estimate for compound 4 lay 1.4-fold (0.15 log units) above the measured number, and the stated range covers the measured number.
By their numbers in this assay, from the lowest: compounds 1, 2, 4 and 3 (each within the scatter of the next, the first and the last beyond it).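

In this assay, the aryl on the aromatic carbon ortho to a cyano group can change from 3,4,5-trimethoxyphenyl, with 12 heavy atoms and 3 hydrogen-bond acceptors, to 4-methylphenyl, with 7 heavy atoms and no acceptors, at a 1.4-fold higher number from compound 1 to compound 4 (0.15 log units; within the scatter). For this pair, the methoxy groups are therefore not required to hold the number within the scatter. Nothing available explains this step.

Going by these compounds, it remains open whether a single methoxy group, a hydroxyl or an amine on this aryl would shift the number. On these data alone, the same exchange alongside the amino aryls of compound 2 and compound 3 is also open.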